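A few compounds are considered here, and "the series" means these few. Any claim that something is new, unique, unknown or untested is made for them only; others in the source may bear on it.

Measured compounds:
Compound 1 `N#Cc1ccc(-n2ncc3c(N)ncnc32)cc1` — "not determined" (no result reported)
Compound 2 `Nc1ncnc2c1cnn2-c1ccc(C(=O)O)cc1` — "not determined" (no result reported)
Compound 3 `N#Cc1cnn(-c2ccc(C(F)(F)F)cc2)c1N` — > 150000 nM

In a functional assay on SF-268 cells (Homo sapiens) for inhibition, with a stated time of 48 h (on this read-out higher numbers stand for weaker inhibition of growth and lower numbers for stronger inhibition of growth), compound 1 gives "not determined" (no result reported), and compound 2 likewise gives "not determined" (no result reported), so neither contributes a number. For compound 3 the entry > 150000 nM is a limit of the assay and not a number. Compound 3 therefore stands as the only entry of the three with any reading at all, and that reading is a limit; the line the limit of > 150000 nM in this assay, at which 1 of the 3 values shown sits, records that one of the three values sits there. Between the measured compounds no step of known size exists, since compound 1 and compound 2 carry no result and compound 3 carries only a limit.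

Compound 4 `N#Cc1cnn(-c2ccc([N+](=O)[O-])cc2)c1N` is the next compound to be measured. It differs from compound 3 as follows: nitro in place of trifluoromethyl on an aromatic carbon.

Given that compound 3 sits at the limit > 150000 nM, the step that the limit leaves unreadable from compound 3 to compound 4 in this assay is expected to be no larger than the scatter, in either direction. Compound 4 is estimated at 200000 nM, with a range from 50000 nM to 800000 nM, and a further limit rather than a number is the expected outcome for compound 4.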

Compound 4, concentration for 50% growth inhibition: 135000 nM
Compound 4: middle estimate off by 1.5-fold (0.17 log units), on the high side; low and high end bracket the measured number.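

In this assay, among these compounds, compound 4 gives 135000 nM, the first number, and nitro in place of trifluoromethyl on an aromatic carbon gives an at least 1.1-fold lower number from compound 3 to compound 4 (0.04 log units; that floor lies within the scatter). Compound 3 stands at > 150000 nM, which is a limit of the assay and not a number. This exchange at this position therefore shows no shift that can be stated as beyond the scatter, and the step has only a floor and no measured size because one end of it is a limit: the limit of > 150000 nM in this assay, at which 1 of the 4 values shown sits.

What an amine or a carboxylic acid in this same place would give on the core of compound 3 stays open, so the two groups shown do not yet define any trend at this position. Steps to compound 1 and compound 2 cannot be read, as neither has a reported result, and whether the core of compound 1 reads differently from the core of compound 3 also stays open.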